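This account rests on a few compounds, and the source may have more. Where it says the series, first, only, none or still open, it means among the compounds named here.

Measured compounds: compound 1 `CCCCC[Se]c1nc(NCc2ccc(SC)cc2)c2ccccc2n1`, compound 2 `CCCCC[Se]c1nc([Se]CCCCC)c2ccccc2n1` and compound 3 `Sc1nc(NCc2ccccc2)c2ccccc2n1`.

In a functional assay on MCF7 cells (Homo sapiens) for cytotoxicity, read by MTT assay, with a stated time of 72 h (on this read-out higher numbers stand for weaker inhibition of growth and lower numbers for stronger inhibition of growth), compound 1 gives 65000 nM and compound 2 gives 95100 nM. For compound 3 this assay reports only a limit, > 100000 nM. Compound 3 thus stands at the limit of > 100000 nM in this assay, at which 1 of the 3 values shown sits, and its distance to the other two cannot be stated. Compound 4 `CCCCC[Se]c1nc(NCc2ccccc2)c2ccccc2n1` differs from compound 3 by a group of 6 heavy atoms (5 carbon, 1 selenium; no ring) in place of one sulfur atom, on an aromatic carbon. For the measured compounds named here, no step between measured compounds is available. Going by the values given here, the entering group is the one carried by compound 1 at 65000 nM and by compound 2 at 95100 nM, both measurable numbers. Compound 4 is therefore expected to show a step of an at least 1.4-fold lower number from compound 3 to compound 4 (0.15 log units; that floor lies within the scatter) from the limit into the measurable range. Compound 4 is estimated at 70000 nM, between 30000 nM and 150000 nM.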

Compound 4, concentration for total growth inhibition: 47100 nM
Compound 4: middle estimate off by 1.5-fold (0.17 log units), on the high side; measured number inside the range.
By their numbers in this assay, from the lowest: compounds 4, 1 and 2 (each within the scatter of the next, the first and the last beyond it). At a limit, above all of these: compound 3.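

On the aromatic carbon between two ring nitrogen atoms, the group of 6 heavy atoms (5 carbon, 1 selenium) in place of sulfanyl gives in this assay an at least 2.1-fold lower number from compound 3 to compound 4 (0.32 log units; beyond the scatter). Compound 3 stands at a limit, so this step is only a floor: the limit of > 100000 nM in this assay, at which 1 of the 4 values shown sits.

On the other substituted aromatic carbon, a group with one six-membered aromatic ring of carbon only in place of the selenium group gives a 2.0-fold lower number from compound 2 to compound 4 (0.31 log units; beyond the scatter), while hydrogen in place of methylsulfanyl on an aromatic carbon gives a 1.4-fold lower number from compound 1 to compound 4 (0.14 log units; within the scatter).

The compounds shown leave open whether a longer chain, a methyl group or an amine on the carbon between the ring nitrogen atoms would shift the number further. They also leave open how a pentyl chain attached through sulfur would compare with the selenium group.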